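Notes on the step from compound 1 to compound 4

The source may hold more compounds than are shown below. What is called first, only, known or untested is meant among the compounds shown, and "the series" means these compounds.

Among the measured compounds shown here, in an ADME assay on cells (Homo sapiens) for cytotoxicity, read by resazurin assay, with a stated time of 5 days (on this read-out higher numbers stand for lower toxicity in this test and lower numbers for higher toxicity in this test), compound 1 (`COc1ccc(Nc2nc(CS(=O)(=O)c3cccc(Cl)c3)nc3ccsc23)cc1`) gives 60000 nM as the only exact number. Compound 2 (`COc1ccc(-c2nc(CSc3ccc(C(F)(F)F)cn3)nc3ccsc23)cn1`) reads > 50000 nM and this is a limit of the assay, not a number. Compound 3 (`COc1ccc(-c2nc(CSc3cc(C)cc(C)c3)nc3ccsc23)cn1`) reads > 50000 nM and this too is a limit. The remaining reference point is thus the limit of > 50000 nM in this assay, at which 2 of the 3 values shown sit, and nothing finer. For the measured compounds named here, no two measured compounds differ in one place, so no measured step is available to size a change.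

Compound 4 (`O=c1ccc(-c2nc(CS(=O)(=O)c3cccc(Cl)c3)nc3ccsc23)c[nH]1`) differs from compound 1 as follows: a group of 7 heavy atoms (5 carbon, 1 nitrogen, 1 oxygen; one six-membered aromatic ring with 1 hetero atom) in place of a group of 9 heavy atoms (7 carbon, 1 nitrogen, 1 oxygen; one six-membered aromatic ring of carbon only), on an aromatic carbon and the (4-methoxyphenyl)amino group is the part that leaves. The new group sits on an aromatic carbon. With compound 1 at 60000 nM as the only anchor, no shift beyond the usual scatter is expected in this assay in either direction. The expected change, a 1.2-fold lower number from compound 1 to compound 4 (0.08 log units; within the scatter), is therefore a small one. For compound 4 the estimated value is 50000 nM with an expected range from 20000 nM to 100000 nM and a report as a limit alone is also expected to be quite likely.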

Compound 4, half-maximal cytotoxic concentration: > 50000 nM
Compound 4 gave a limit, no number; the forecaster's own chance of this, stated with the estimate: 55%; the middle value sits exactly at the limit.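

In this assay compound 4 gives > 50000 nM, which is a limit of the assay and not a number. Among the compounds shown here, no step from compound 1 to compound 4 can be read from it. The compounds shown leave open whether replacing the (4-methoxyphenyl)amino group shifts this read-out at all, and the series offers little finer to compare against: the limit of > 50000 nM in this assay, at which 3 of the 4 values shown sit.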